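Adding a chloro to compound 2

The source may hold more compounds than are shown below. What is called first, only, known or untested is meant among the compounds shown, and "the series" means these compounds.

Measured in a functional assay on CLL cells (Homo sapiens) for cytotoxicity, read by MTT assay, with a stated time of 48 h; a lower number here means that less compound is needed, a higher number that more compound is needed for the effect:
Compound 1 `C=C(CC)C(=O)c1ccc(OCC(=O)Nc2ccc(C(=O)O)cn2)c(Cl)c1Cl`: 14900 nM
Compound 2 `C=C(CC)C(=O)c1ccc(OCC(=O)Nc2cccc(C(=O)O)c2)c(Cl)c1Cl`: 20600 nM
Compound 3 `C=C(CC)C(=O)c1ccc(OCC(=O)Nc2ccc(O)c(Cl)c2)c(Cl)c1Cl`: 5500 nM

Compound 2, at 20600 nM, sits at the upper end of these numbers, level with compound 1 within the scatter: the measured step is a 1.4-fold higher number from compound 1 to compound 2 (0.14 log units; within the scatter). The clear gaps involve compound 3, namely a 3.7-fold lower number from compound 2 to compound 3 (0.57 log units; beyond the scatter) and a 2.7-fold lower number from compound 1 to compound 3 (0.43 log units; beyond the scatter).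

Compound 4 `C=C(CC)C(=O)c1ccc(OCC(=O)Nc2ccc(Cl)c(C(=O)O)c2)c(Cl)c1Cl` differs from compound 2 by a single change: chloro in place of hydrogen on an aromatic carbon. The chloro sits ortho to a carboxy group and para to a large group. For the measured compounds named here, no measured step isolates this change. The nearest evidence is a 3.7-fold lower number from compound 2 to compound 3 (0.57 log units; beyond the scatter), but that swap to 3-chloro-4-hydroxyphenyl also removes the carboxy group, which compound 4 keeps, so it offers only weak guidance. Only a small drop in this assay is therefore expected, and it may stay within the scatter. The estimate amounts to an expected 1.6-fold lower number from compound 2 to compound 4 (0.20 log units; within the scatter). For compound 4 the expected value is 13000 nM, with a range of 6000 nM to 26000 nM.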

Compound 4, half-maximal effective concentration: 15900 nM
Compound 4: middle estimate off by 1.2-fold (0.09 log units), on the low side; the measured number falls inside the stated range.
By their numbers in this assay, from the lowest: compound 3; then compounds 1, 4 and 2 (each within the scatter of the next).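

In this assay, chloro in place of hydrogen on an aromatic carbon, ortho to a carboxy group and para to a large group, gives a 1.3-fold lower number from compound 2 to compound 4 (0.11 log units; within the scatter), so this direct test of the position shows no shift beyond the scatter. With the carboxy group kept, adding the chloro alone does not produce a step of the size of a 3.7-fold lower number from compound 2 to compound 3 (0.57 log units; beyond the scatter), the swap that also removes the carboxy group. Nothing in the data at hand bears on why this step is so small.

Going by these compounds, whether a fluoro, a methyl or an amine at this same position would behave as the chloro does remains open. Also open, on these data alone, is whether the hydroxy group of compound 3, rather than its chloro, goes with that compound's lower number.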